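Cytotoxicity notes on the lactam series, compound 3

This account rests on a few compounds, and the source may have more. Where it says the series, first, only, none or still open, it means among the compounds named here.

compound 1 `COc1ccc([C@H]2CC(=O)N(Cc3cccc([N+](=O)[O-])c3)C2)cc1OC1CCCC1`: > 10000 nM
compound 2 `COc1ccc([C@H]2CC(=O)N(c3cccc(C#N)c3)C2)cc1OC1CCCC1`: > 10000 nM

In a functional assay on HEK293 cells (Homo sapiens) for cytotoxicity (on this read-out higher numbers stand for lower toxicity in this test and lower numbers for higher toxicity in this test), compound 1 reaches only the assay limit, > 10000 nM. Compound 2 likewise sits at a limit in this assay, > 10000 nM. Going by the values given here, the only measured step, a step that the two limits leave unreadable from compound 1 to compound 2, is therefore unreadable; the shared position is the limit of > 10000 nM in this assay, at which 2 of the 2 values shown sit.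

Compound 3 `COc1ccc([C@H]2CC(=O)N(c3cccc(C(F)(F)F)c3)C2)cc1OC1CCCC1` differs from compound 1 by 3-(trifluoromethyl)phenyl in place of 3-nitrobenzyl on an amide-type nitrogen in a ring. Among the compounds with values here, no measured step bears readably on this change, so no step beyond the scatter is expected; the estimated step is a step that the limit leaves unreadable from compound 1 to compound 3. Compound 3 is expected at 15000 nM, range 6000 nM to 40000 nM, most likely again reported as a limit.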

Compound 3, half-maximal cytotoxic concentration: > 10000 nM
Compound 3 gave a limit, no number; the forecaster's own chance of this, stated with the estimate: 80%; the middle value lies beyond the limit too.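

Compound 3 also sits at a limit, > 10000 nM, in this assay, and its steps from compound 1 and compound 2 cannot be read. The compounds shown leave open how any of these groups on the ring nitrogen ranks on cytotoxicity, with all values at one limit: the limit of > 10000 nM in this assay, at which 3 of the 3 values shown sit.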